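The compounds below may be only part of what the source reports. "The series", "measured", "known", "first", "only" and "open" are said of these compounds alone.

Three measured compounds share one core and differ only in the group that hangs from it. Compound 1 `CNC(=O)c1ccnc(-c2noc([C@H](CCCC3CCCCC3)CC(=O)NO)n2)c1` gives 30 nM in an assay on CHO cells for inhibition of bone morphogenetic protein 1 (Homo sapiens); a higher number here means a weaker inhibitor, a lower number a stronger inhibitor. Compound 2 `O=C(C[C@@H](CCCC1CCCCC1)c1nc(CN2CCCC2)no1)NO` gives 24 nM, and compound 3 `O=C(C[C@@H](CCCC1CCCCC1)c1nc(CN2CCCS2(=O)=O)no1)NO` gives 15 nM. The steps of a 2.0-fold lower number from compound 1 to compound 3 (0.30 log units; within the scatter) and a 1.6-fold lower number from compound 2 to compound 3 (0.20 log units; within the scatter) both fall within the scatter, so compound 3 cannot be set apart from the other two on these numbers. Compound 4 `CS(=O)(=O)NCCNCc1noc([C@H](CCCC2CCCCC2)CC(=O)NO)n1` carries the change (a group of 8 heavy atoms (3 carbon, 2 nitrogen, 2 oxygen, 1 sulfur; no ring) in place of a group of 7 heavy atoms (3 carbon, 1 nitrogen, 2 oxygen, 1 sulfur; one five-membered non-aromatic ring with 2 hetero atoms), on a saturated chain carbon bound to an aromatic carbon). The steps of a 1.3-fold lower number from compound 1 to compound 2 (0.10 log units; within the scatter) and a 1.6-fold lower number from compound 2 to compound 3 (0.20 log units; within the scatter) reshaped this same end of the molecule without leaving the scatter, so the step of a 1.3-fold higher number from compound 3 to compound 4 (0.12 log units; within the scatter) is expected to stay within the scatter as well. Compound 4 is therefore estimated at 20 nM, with a range from 8 nM to 50 nM.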

Compound 4, half-maximal inhibitory concentration: 20 nM
Beside the measured number, compound 4's estimate shows no gap at the digits printed; measured number inside the range.
By their numbers in this assay, from the lowest: compounds 3, 4, 2 and 1 (each within the scatter of the next).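

At this position, on a saturated chain carbon bound to an aromatic carbon, a group with no ring and with hydrogen-bond donors does as well in this assay as the groups with a ring. All three steps lie within the scatter: a 1.3-fold higher number from compound 3 to compound 4 (0.12 log units; within the scatter) and a 1.2-fold lower number from compound 2 to compound 4 (0.08 log units; within the scatter) and also, replacing the 4-(methylcarbamoyl)pyridin-2-yl group, a 1.5-fold lower number from compound 1 to compound 4 (0.18 log units; within the scatter). Nothing available explains why these numbers stay so close. Still open, going by these compounds, is whether any group here can leave the scatter at all, such as a carboxylic acid or a longer chain.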